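Thioether ring swap in the hydrazone series: compound 2 to compound 4

The source may report more compounds than this note shows. Statements on the series, on what has been measured and on what is new or still open speak of the compounds shown alone.

Measured compounds and their numbers in a functional assay on C6 cells (Rattus norvegicus) for cytotoxicity, read by MTT assay, with a stated time of 24 h, tested at 25 ug/mL; a higher number here means a weaker effect of the compound at the concentration tested, a lower number a stronger effect:
- compound 1, `O=C(CSc1ncccn1)N/N=c1/scc(-c2ccc(Br)cc2)n1-c1ccccc1`, gives 72.3%
- compound 2, `O=C(CSc1ncccn1)N/N=c1/scc(-c2ccc(F)cc2)n1-c1ccccc1`, gives 63.9%
- compound 3, `O=C(CSc1nnnn1-c1ccccc1)N/N=c1/scc(-c2ccccc2)n1-c1ccccc1`, gives 42.5%

Compound 2 sits second highest of the three numbers. Its nearest neighbour is compound 1, reached by a number 8.4 percentage points lower from compound 1 to compound 2 (within the scatter), a step that lies within the usual scatter. Going by the values given here, its furthest neighbour is compound 3, whose number is lower by a margin beyond the scatter; compound 3 differs from compound 2 in more than one place, so no single step connects them.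

Compound 4, `Cc1nnc(SCC(=O)N/N=c2/scc(-c3ccc(F)cc3)n2-c2ccccc2)s1`, is not yet measured. It differs from compound 2 only at the sulfur: 5-methyl-1,3,4-thiadiazol-2-yl in place of pyrimidin-2-yl on a sulfur.

Among the compounds with values here, no measured step changes the ring on the sulfur alone. Within the data shown here, the one measured step, from compound 1 to compound 2, exchanges the halogen on the aryl ring and stays within the scatter, so it says nothing about this change. Compound 3 carries a different five-membered ring on the sulfur and shows the lowest number, but its halogen is also absent, so the two changes cannot be separated.

Among the measured compounds shown here, with no clean precedent, compound 4 is expected to give 58%, with a range from 40% to 75%. The expected step is a number 5.9 percentage points lower from compound 2 to compound 4 (within the scatter), which is estimated to stay within the scatter.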

Compound 4, a percentage reported as activity, at one concentration (the size of the read-out at that concentration, not a potency): 50.1%
Estimate against measurement, compound 4: 7.9 percentage points above; the range from low to high includes it.
By their numbers in this assay, from the lowest: compounds 3 and 4 (each within the scatter of the next); then compounds 2 and 1 (each within the scatter of the next).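

In this assay, going by these compounds alone, the ring on the sulfur is the first place where a single change gives a step beyond the scatter: 5-methyl-1,3,4-thiadiazol-2-yl in place of pyrimidin-2-yl gives a number 13.8 percentage points lower from compound 2 to compound 4 (beyond the scatter), which means a stronger effect at the concentration tested. Within the data shown here, the only earlier single-place step, the halogen exchange on the aromatic carbon, gave a number 8.4 percentage points lower from compound 1 to compound 2 (within the scatter) and stayed within the scatter, so among the steps in hand the group on the sulfur is the one that moves this read-out, though only modestly and from one pair. Among these compounds, nothing measured so far accounts for the shift.

As far as these compounds go, it remains open whether the same ring exchange gives a step of similar size with bromo in place of fluoro on the aromatic carbon, and whether the step comes from the thiadiazole ring itself or from its methyl group. Also open, from the compounds shown here alone, is what a plain ethyl chain or a carboxylic acid on the chain at the sulfur would do to the read-out in this assay.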